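Furan-3-yl Replaces Imidazolyl in a Cyanoacrylate Ester Series

The compounds below may be only part of what the source reports. "The series", "measured", "known", "first", "only" and "open" are said of these compounds alone.

Compound 1 `N#C/C(=C\c1ccc(O)c(O)c1)C(=O)N1CCOCC1`: 40%
Compound 2 `CCOC(=O)/C(C#N)=C/c1c[nH]cn1`: 33%
Compound 3 `N#C/C(=C\c1c[nH]cn1)C(=O)OC1CCCCC1`: 50%

In a functional assay on the whole organism (strain CD1) for inhibition, with Mus musculus as the target, with stated times of 15 min and 20 min, at a dose of 10 mg/kg by the subcutaneous route (a lower number here means less inhibition, a higher number more inhibition at the dose given (going by the name of the read-out)), compound 3 gives the highest of the three numbers; compound 1 sits within the scatter of it, while compound 2 lies beyond it. Going by the values given here, the only single-site step measured is a number 17 percentage points higher from compound 2 to compound 3 (beyond the scatter), which concerns the ester and not the aromatic ring. Compound 4 `N#C/C(=C\c1ccoc1)C(=O)OC1CCCCC1` differs from compound 3 in one place: furan-3-yl in place of 1H-imidazol-4-yl on a double-bonded chain carbon bound to a double-bonded chain carbon. Among the compounds with values here, no measured step touches this ring exchange, so it offers no guide to direction or size. Compound 4 is therefore expected to stay near compound 3, with a step of a number 8 percentage points lower from compound 3 to compound 4 (within the scatter) in this assay carrying wide uncertainty. The estimate for compound 4 is 42%, within 15% to 65%.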

Compound 4, a percentage reported as inhibition, in the whole organism at one dose (the size of the read-out at that dose, not a potency): 91.2%
For compound 4 the middle estimate is 49.2 percentage points below the measured one; measured number outside the range, above it.
By their numbers in this assay, from the lowest: compounds 2, 1 and 3 (each within the scatter of the next, the first and the last beyond it); then compound 4.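

In this assay, furan-3-yl in place of 1H-imidazol-4-yl on a double-bonded chain carbon bound to a double-bonded chain carbon brings a number 41.2 percentage points higher from compound 3 to compound 4 (beyond the scatter). This shows that the ring at this place, which the earlier step at the ester did not touch, can move the read-out strongly, and that the imidazole hydrogen-bond donor is not required for inhibition here. Nothing available accounts for the gain.

On these data alone, whether it is specific to furan-3-yl or would also appear with a phenyl group at this place remains open. So does whether it would carry over to the ethyl ester of compound 2.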